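Chloro in Place of Methyl on the Sulfonyl Aryl Ring

The source may report more compounds than this note shows. Statements on the series, on what has been measured and on what is new or still open speak of the compounds shown alone.

Compound 2 `CC1=NC(c2cn(S(=O)(=O)c3ccc(C)cc3)c3ccccc23)CN1` is the reference point of this account. In an assay on isolated protein for inhibition of kallikrein-7 (Homo sapiens), read by fluorescence, with stated times of 10 min and 30 min (on this read-out lower numbers stand for stronger inhibition and higher numbers for weaker inhibition), compound 2 gives 10000 nM, the lowest of the three numbers recorded so far. Compound 1 `Cc1ccc(S(=O)(=O)n2cc(C3CNC(C(C)C)=N3)c3ccccc32)cc1` gives 70000 nM in this assay, and compound 3 `CCC1=NC(c2cn(S(=O)(=O)c3ccc(C)cc3)c3ccccc23)CN1` gives 24000 nM. The measured steps are a 7.0-fold lower number from compound 1 to compound 2 (0.85 log units; beyond the scatter), a 2.9-fold lower number from compound 1 to compound 3 (0.46 log units; beyond the scatter) and a 2.4-fold higher number from compound 2 to compound 3 (0.38 log units; beyond the scatter). Every one of these steps alters the group on the carbon with a double bond to nitrogen or on the saturated chain carbon bound to it; none of them touches the aromatic ring carried by the sulfonyl group, and the 4-methylphenyl part is the same in all three compounds.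

Compound 4 `CC1=NC(c2cn(S(=O)(=O)c3ccc(Cl)cc3)c3ccccc23)CN1` differs from compound 2 in exactly that untouched part: chloro in place of methyl on an aromatic carbon. Among the measured compounds shown here, no measured step therefore bears directly on this change, and the data give no basis for predicting a shift in either direction. He expects the step from compound 2 to compound 4 to stay within the scatter, no change at the digits printed from compound 2 to compound 4 (within the scatter). Compound 4 is accordingly estimated at 10000 nM in this assay, with a range from 3000 nM to 35000 nM.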

Compound 4, half-maximal inhibitory concentration: 5700 nM
For compound 4 the middle estimate is 1.8-fold (0.24 log units) above the measured one; the range from low to high includes it.
By their numbers in this assay, from the lowest: compounds 4 and 2 (each within the scatter of the next); then compound 3; then compound 1.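

In this assay, among the compounds shown here, the aromatic ring carried by the sulfonyl group is now probed for the first time, and the result is a 1.8-fold lower number from compound 2 to compound 4 (0.24 log units; within the scatter). So 4-methylphenyl to 4-chlorophenyl, on an aromatic carbon para to a large group, is a change this read-out does not separate from repeat measurement, unlike the three earlier steps at the carbon with a double bond to nitrogen or the saturated chain carbon bound to it, all of which were printed as beyond the scatter. No measurement to hand gives a reason for this result.

The compounds shown carry only methyl and chloro at this place, so what an amine, a methoxy group or a carboxylic acid there would give in this assay stays open. For the compounds shown here, also open is whether chloro in place of methyl would read the same on the shared core of compound 1 or compound 3, since this change is seen only with the methyl group of compound 2 on the carbon with a double bond to nitrogen.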